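A few compounds are considered here, and "the series" means these few. Any claim that something is new, unique, unknown or untested is made for them only; others in the source may bear on it.

Three compounds measured in a physicochemical assay for lipophilicity, at pH 7.4 (on this read-out higher numbers stand for higher lipophilicity and lower numbers for lower lipophilicity), set the scene. Compound 1 `CNC(=O)c1cc(C(=O)NC2CC2)cn(Cc2ccc(C)cc2)c1=O` gives 3.5 in this assay. Compound 2 `CCNC(=O)c1cccn(Cc2ccccc2)c1=O` gives 3.7, and compound 3 `CNC(=O)c1cc(C(=O)NC2CCC2)cn(Cc2cccnc2)c1=O` gives 1.8. Among these three numbers compound 1 stands second highest. Its nearest neighbour is compound 2, whose value lies a little above it, but the two are within the usual scatter of the method, so no order between them can be claimed. Its furthest neighbour is compound 3, whose value lies well below, a gap that is clearly beyond the scatter.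

From compound 1 the piece now steps to compound 4 `CNC(=O)c1cc(C(=O)NC2CC2)cn(CC2CCOCC2)c1=O`, which has not yet been measured. The change is oxan-4-yl in place of 4-methylphenyl on a saturated chain carbon bound to an aromatic nitrogen: the 4-methylphenyl group leaves and oxan-4-yl enters, so an aromatic ring of carbon only gives way to a saturated ring carrying one oxygen that can accept a hydrogen bond.

Going by the values given here, no step between two measured compounds that differ in only this one place is available, so the size of the change must be estimated. A downward step in this assay, clearly beyond the scatter, is expected, and compound 4 is estimated at 1.8, with a likely range from 1.2 to 2.4; the expected step is a number 1.70 log units lower from compound 1 to compound 4 (beyond the scatter).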

Compound 4, distribution coefficient: 1.5
Compound 4: the middle estimate sits 0.30 log units above what was measured, and the stated range covers the measured number.
By their numbers in this assay, from the lowest: compounds 4 and 3 (each within the scatter of the next); then compounds 1 and 2 (each within the scatter of the next).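

In this assay, replacing 4-methylphenyl with oxan-4-yl on a saturated chain carbon bound to an aromatic nitrogen gives a number 2.00 log units lower from compound 1 to compound 4 (beyond the scatter), a large step that gives this place its first directly measured change. Going by these compounds alone, none of the earlier compounds formed a pair differing only here, so this step is the first to show that the read-out can respond strongly to this single exchange while the rest of the structure stays the same. The exchange alters several features together, with an aromatic ring of carbon only giving way to a non-aromatic ring with one oxygen and one hydrogen-bond acceptor, and no available evidence separates their contributions.

Still open, going by these compounds, is how much of the step follows the loss of the aromatic ring and how much follows the arrival of the oxygen, a question that cyclohexyl at the same place could help to separate. On these data alone, it also remains open how this read-out would respond to an amine in the ring, as in piperidin-4-yl, or to a carboxylic acid on the same chain.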